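A few compounds are considered here, and "the series" means these few. Any claim that something is new, unique, unknown or untested is made for them only; others in the source may bear on it.

Of the compounds shown here, three have been tested in a functional assay for inhibition, tested at 0.1 mM; a lower number here means less inhibition, a higher number more inhibition at the concentration tested (going by the name of the read-out). Compound 3 `CNC(=S)NNC(=O)Cn1c(-c2ccc(OC)c(OC)c2)nc2cc(Cl)c(Cl)cc21` gives 26% in this assay, the highest of the three numbers, but compound 1 `CNc1nnc(Cn2c(-c3ccc(Cl)cc3)nc3ccccc32)s1` gives 21% in this assay, a value within the usual scatter of that of compound 3, while compound 2 `COc1ccc(-c2nc3ccccc3n2Cc2n[nH]c(=S)n2C)cc1` gives 5% in this assay, a gap beyond the scatter.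

Compound 4 `CNc1nnc(Cn2c(-c3ccc(OC)c(OC)c3)nc3cc(Cl)c(Cl)cc32)s1` is derived from compound 3 by one change: a group of 7 heavy atoms (3 carbon, 3 nitrogen, 1 sulfur; one five-membered aromatic ring with 3 hetero atoms) in place of a group of 8 heavy atoms (3 carbon, 3 nitrogen, 1 oxygen, 1 sulfur; no ring), on a saturated chain carbon bound to an aromatic nitrogen. Compound 1 already carries the same 5-(methylamino)-1,3,4-thiadiazol-2-yl group and gives 21%, so for compound 4 the step of a number 2 percentage points lower from compound 3 to compound 4 (within the scatter) is expected to stay within the scatter, with no clear direction. Compound 4 is therefore estimated at 24%, within a range of 10% to 40%.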

Compound 4, a percentage reported as inhibition, at one concentration (the size of the read-out at that concentration, not a potency): 31%
Compound 4: the middle estimate sits 7 percentage points below what was measured; low and high end bracket the measured number.
By their numbers in this assay, from the lowest: compound 2; then compounds 1, 3 and 4 (each within the scatter of the next).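

In this assay, putting 5-(methylamino)-1,3,4-thiadiazol-2-yl in place of the open group without a ring, on a saturated chain carbon bound to an aromatic nitrogen, gives a number 5 percentage points higher from compound 3 to compound 4 (within the scatter) and so separates neither group from the other. Among the compounds shown here, this is the first pair here that differs in one place, and it shows that this position accepts either the ring or the open group with no step beyond the scatter. Nothing available explains why the two groups read alike.

On these data alone, whether a carboxylic acid, an amine or a longer chain at this position would move the number beyond the scatter stays open. The compounds shown also leave open whether the same change would give a similar step on a different core.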